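Replacing the 4-vinylphenyl group of compound 2

The source may hold more compounds than are shown below. What is called first, only, known or untested is meant among the compounds shown, and "the series" means these compounds.

In a functional assay on B16-F0 cells (Mus musculus) for inhibition, read by CCK-8 assay, with a stated time of 48 h (on this read-out lower numbers stand for stronger inhibition and higher numbers for weaker inhibition), compound 1 `COc1cc(-c2ccnc3cc(-c4ccc(F)cc4)nn23)cc(OC)c1OC` gives 4540 nM and compound 2 `C=Cc1ccc(-c2cc3nccc(-c4cc(OC)c(OC)c(OC)c4)n3n2)cc1` gives 788 nM as the lower of the two numbers. Among the measured compounds shown here, the only measured step is a 5.8-fold lower number from compound 1 to compound 2 (0.76 log units; beyond the scatter) and it comes with vinyl in place of fluoro on an aromatic carbon. Compound 3 `COc1ccc(-c2cc3nccc(-c4cc(OC)c(OC)c(OC)c4)n3n2)cc1F` keeps the shared core, and its difference from compound 2 is 3-fluoro-4-methoxyphenyl in place of 4-vinylphenyl on an aromatic carbon which puts 3-fluoro-4-methoxyphenyl in place of 4-vinylphenyl. For the measured compounds named here, compound 3 loses the vinyl and carries a fluoro, like compound 1 at 4540 nM so the single step of a 5.8-fold lower number from compound 1 to compound 2 (0.76 log units; beyond the scatter) is the only guide, and no measured compound carries a methoxy on this ring. A modest move towards a higher number in this assay is therefore expected. The estimated change is a 2.3-fold higher number from compound 2 to compound 3 (0.36 log units; beyond the scatter) on this reasoning. Compound 3 is estimated at 1800 nM within an expected range of 500 nM to 5500 nM once tested.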

Compound 3, half-maximal inhibitory concentration: 3950 nM
For compound 3 the middle estimate is 2.2-fold (0.34 log units) below the measured one; measured number inside the range.
By their numbers in this assay, from the lowest: compound 2; then compounds 3 and 1 (each within the scatter of the next).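

In this assay this carbon of the five-membered aromatic ring responds clearly to the group it carries, with a 5.0-fold higher number from compound 2 to compound 3 (0.70 log units; beyond the scatter) on exchanging 4-vinylphenyl for 3-fluoro-4-methoxyphenyl. The two fluorinated rings cannot be told apart, as a 1.1-fold lower number from compound 1 to compound 3 (0.06 log units; within the scatter) shows, so among the three compounds only the 4-vinylphenyl compound stands out, and the methoxy-bearing ring does not recover its lower number. No supporting data bear on why this ring gives the lower number.

As far as these compounds go, it remains open whether the vinyl group itself matters, or whether an ethyl group, a nitrile or an amine in its place on the phenyl ring would give a similar number. A longer chain ending in a double bond would also show whether more of the same kind of group lowers the number further.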